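The source may hold more compounds than are shown below. What is called first, only, known or untested is meant among the compounds shown, and "the series" means these compounds.

Measured compounds in the series:

Compound 1, `COc1ccc(/C=C2\C(=O)N(Cc3cn([C@@H]4O[C@H](COC(C)=O)[C@@H](OC(C)=O)[C@H](OC(C)=O)[C@H]4OC(C)=O)nn3)c3ccccc32)cc1OC`: 63400 nM
Compound 2, `CC(=O)OC[C@H]1O[C@@H](n2cc(CN3C(=O)/C(=C\C=C\c4ccccc4)c4ccccc43)nn2)[C@H](OC(C)=O)[C@@H](OC(C)=O)[C@@H]1OC(C)=O`: 98100 nM

Both numbers come from a functional assay on HeLa cells (Homo sapiens) for cytotoxicity, read by sulforhodamine B assay, with a stated time of 48 h; on this read-out higher numbers stand for weaker inhibition and lower numbers for stronger inhibition. Among the compounds with values here, compound 2 stands with the highest of the two numbers; its nearest neighbour is compound 1, and the only step that joins them, a 1.5-fold higher number from compound 1 to compound 2 (0.19 log units; within the scatter), lies within the scatter, so no order between compound 1 and compound 2 can be read from this assay.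

Compound 3, `CC(=O)OC[C@H]1O[C@@H](n2cc(CN3C(=O)/C(=C\c4ccc5ccccc5c4)c4ccccc43)nn2)[C@H](OC(C)=O)[C@@H](OC(C)=O)[C@@H]1OC(C)=O`, is not yet measured. It differs from compound 2 in one place: naphthalen-2-yl in place of 2-phenylethenyl on a double-bonded chain carbon bound to a double-bonded ring carbon. Within the data shown here, the single measured step that bears on this position is the one from compound 1 to compound 2, an exchange of groups at the same chain carbon, and it was within the scatter. On that basis the exchange for naphthalen-2-yl is expected to move this assay little, with no clear direction beyond the scatter; the step from compound 2 to compound 3 is estimated as a 1.4-fold lower number from compound 2 to compound 3 (0.15 log units; within the scatter). For compound 3 the expected value in this assay is 70000 nM, with a range from 30000 nM to 160000 nM.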

Compound 3, half-maximal inhibitory concentration: > 100000 nM
Compound 3 ended at the assay's limit; the forecaster's own chance of this, stated with the estimate: 20%; middle value at least 1.4-fold (0.15 log units) from the limit.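

In this assay compound 3 gives > 100000 nM, which is a limit of the assay and not a number. Naphthalen-2-yl on the double-bonded chain carbon bound to a double-bonded ring carbon gives only floors for its two steps, an at least 1.0-fold higher number from compound 2 to compound 3 (0.00 log units; that floor lies within the scatter) and an at least 1.5-fold higher number from compound 1 to compound 3 (0.19 log units; that floor lies within the scatter), and as both floors lie within the scatter, no order among compound 1, compound 2 and compound 3 can be read. What this adds is a third group at this place, with two aromatic rings of carbon in place of one, that gives no sign of stronger inhibition, while the series now also touches the top of the measurable range: the limit of > 100000 nM in this assay, at which 1 of the 3 values shown sits.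

As far as these compounds go, how far compound 3 lies past its limit stays open, so the size of the change to naphthalen-2-yl cannot be fixed. Also open, from the compounds shown here alone, is whether an amine or a carboxylic acid carried at this chain carbon, in place of the groups with only carbon, methoxy or aromatic rings seen so far, would give a number clearly lower than those of compound 1 and compound 2.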